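The source may hold more compounds than are shown below. What is called first, only, known or untested is meant among the compounds shown, and "the series" means these compounds.

In a functional assay on MGC-803 cells (Homo sapiens) for antiproliferative activity, read by MTT assay, with a stated time of 48 h (a lower number here means a stronger inhibitor, a higher number a weaker inhibitor), three compounds that share one core and differ in the group on an amide-type nitrogen have been measured. Compound 1 `Cc1cccc(NC(=O)Nc2cccc(CNc3nccnc3Cl)c2)c1` gives 14600 nM, compound 2 `O=C(Nc1cccc(CNc2nccnc2Cl)c1)Nc1ccc(F)c(Cl)c1` gives 5020 nM, and compound 3 `CCc1ccccc1NC(=O)Nc1cccc(CNc2nccnc2Cl)c1` gives 9370 nM. Among the compounds with values here, compound 3 has no firm rank among them: the data show a 1.6-fold lower number from compound 1 to compound 3 (0.19 log units; within the scatter) and a 1.9-fold higher number from compound 2 to compound 3 (0.27 log units; within the scatter), whereas the only step beyond the scatter is a 2.9-fold lower number from compound 1 to compound 2 (0.46 log units; beyond the scatter).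

Compound 4 `Cc1ccc(NC(=O)Nc2cccc(CNc3nccnc3Cl)c2)cc1` follows from compound 3 through the change (4-methylphenyl in place of 2-ethylphenyl on an amide-type nitrogen), with 4-methylphenyl in place of 2-ethylphenyl on an amide-type nitrogen. Within the data shown here, no measured step makes this exact exchange. The nearest evidence is the exchange of 3-methylphenyl for 2-ethylphenyl, which gave a 1.6-fold lower number from compound 1 to compound 3 (0.19 log units; within the scatter). The data do not show how 4-methylphenyl compares with 3-methylphenyl. No shift beyond the scatter is therefore expected in this assay, and the estimated step is a 1.2-fold higher number from compound 3 to compound 4 (0.07 log units; within the scatter). Compound 4 is expected at 11000 nM, within an estimated range of 5000 nM to 24000 nM.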

Compound 4, half-maximal inhibitory concentration: 11900 nM
The estimate for compound 4 lay 1.1-fold (0.03 log units) below the measured number, and the stated range covers the measured number.
By their numbers in this assay, from the lowest: compounds 2, 3, 4 and 1 (each within the scatter of the next, the first and the last beyond it).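

In this assay the new group gives a 1.3-fold higher number from compound 3 to compound 4 (0.10 log units; within the scatter) and a 1.2-fold lower number from compound 1 to compound 4 (0.09 log units; within the scatter), so 4-methylphenyl, 2-ethylphenyl and 3-methylphenyl on the amide-type nitrogen cannot be told apart in this assay, all three steps among them lying within the scatter. Within the data shown here, the only new step beyond the scatter is the modest 2.4-fold higher number from compound 2 to compound 4 (0.37 log units; beyond the scatter), which sets the 3-chloro-4-fluorophenyl group of compound 2 apart from a second methylphenyl group, although compound 2 and compound 3 remain within the scatter of each other. Nothing available gives a reason for these steps.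

The compounds shown leave open whether the chlorine or the fluorine of compound 2 accounts for its separation from compound 1 and compound 4. They also leave open how a 4-chlorophenyl, a 4-methoxyphenyl or a phenyl bearing a carboxylic acid would fare at this nitrogen.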